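The source may report more compounds than this note shows. Statements on the series, on what has been measured and on what is new or still open speak of the compounds shown alone.

Compound 2, `CNc1nc(NC2(C#N)CCCCC2)nc(-n2cccn2)n1`, belongs to a small set of triazine derivatives tested in an in vitro assay on Sf21 cells for inhibition of high affinity 3',5'-cyclic-AMP phosphodiesterase 7A (Homo sapiens); a lower number here means a stronger inhibitor, a higher number a weaker inhibitor. In this assay compound 2 gives only > 5000 nM, which is a limit of the assay and not a number. The neighbouring compound 1, `CNc1nc(NC2CCCC2)nc(NC2(C#N)CCCCC2)n1`, is the same except that it carries a cyclopentylamino group where compound 2 carries a 1H-pyrazol-1-yl group. In this assay compound 1 likewise gives > 5000 nM, again a limit. The step that the two limits leave unreadable from compound 1 to compound 2 therefore cannot be read, and both values sit at the same limit (the limit of > 5000 nM in this assay, at which 2 of the 2 values shown sit).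

Compound 3, `CNc1nc(NC)nc(NC2(C#N)CCCCC2)n1`, is not yet measured. It differs from compound 2 by methylamino in place of 1H-pyrazol-1-yl on an aromatic carbon. No measured step tells how this assay responds to such a change, so no direction can be inferred from the pair shown; weak inhibition is simply the expectation. Compound 3 is expected to give about 6000 nM, within a range of 1500 nM to 30000 nM. For compound 3 this means an expected step that the limit leaves unreadable from compound 2 to compound 3.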

Compound 3, half-maximal inhibitory concentration: > 1000 nM
Compound 3 gave a limit, no number; the forecaster's own chance of this, stated with the estimate: 70%; the middle value is on the limit's open side.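

In this assay compound 3 gives > 1000 nM, which is a limit and not a number. Among these compounds, compound 1 and compound 2 also stand only at limits, so no step among compound 1, compound 2 and compound 3 can be read. As far as these compounds go, how strongly each inhibits, and whether these group changes matter at all, stays open.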